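The source may report more compounds than this note shows. Statements on the series, on what has been measured and on what is new or still open speak of the compounds shown alone.

In a functional assay on cells (Breast cancer cell line, Homo sapiens) for inhibition (on this read-out lower numbers stand for stronger inhibition of growth and higher numbers for weaker inhibition of growth), three compounds have been measured so far:

Compound 1 `CN1CC2=C(N=C(S)NC2c2cccs2)/C(=C/c2cccs2)C1` gives 98100 nM.
Compound 2 `COc1ccc(/C=C2\CN(C)CC3=C2N=C(S)NC3c2ccc(OC)cc2)cc1` gives 68100 nM.
Compound 3 `CN1C/C(=C\c2cccs2)C2=NN(C)C(c3cccs3)C2C1` gives > 100000 nM.

For compound 3 the value > 100000 nM is a limit of the assay rather than a number, and it stands at the limit of > 100000 nM in this assay, at which 1 of the 3 values shown sits. Compound 4 `CN1C/C(=C\c2cccs2)C2=NN(c3ccccc3)C(c3cccs3)C2C1` differs from compound 3 in one place: phenyl in place of methyl on an amine nitrogen in a ring. Among the compounds with values here, no pair of measured compounds differing in only one place is available, so the effect of this change has not been seen directly. The expected step in this assay is a number no higher from compound 3 to compound 4 (the limit leaves the size open), which is not beyond the usual scatter. Compound 4 is therefore estimated at 100000 nM, with a range from 30000 nM to 300000 nM.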

Compound 4, concentration for total growth inhibition: > 100000 nM
Compound 4 was reported as a limit; the forecaster's own chance of this, stated with the estimate: 60%; the middle value lies on the limit itself.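

Compound 3 and compound 4 are both reported only as a limit, so no step between them can be read: the limit of > 100000 nM in this assay, at which 2 of the 4 values shown sit.

From the compounds shown here alone, whether phenyl in place of methyl changes growth inhibition at all, and in which direction, stays open.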